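Adding One More Carbon to the Side Chain

The source may hold more compounds than are shown below. What is called first, only, known or untested is meant among the compounds shown, and "the series" means these compounds.

Measured so far:
compound 1 `CCC[C@@H](CO)Nc1nc(N)nc2cccnc12` gives 430 nM
compound 2 `CCCC[C@@H](CO)Nc1nc(N)nc2cccnc12` gives 420 nM
compound 3 `CCCC[C@H](CO)Nc1nc(N)nc2cccnc12` gives 790 nM

All three were tested in an assay on tissue (PBMC cells) for agonist activity at Toll-like receptor 8 (Homo sapiens), with a stated time of 24 h; a higher number here means that more compound is needed for the effect, a lower number that less compound is needed. Compound 2 differs from compound 1 by a single added carbon: methyl in place of hydrogen on a saturated chain carbon, four bonds along the chain from a nitrogen on an aromatic ring. The result was a 1.0-fold lower number from compound 1 to compound 2 (0.01 log units; within the scatter), so the two values cannot be told apart. Compound 3 has the same atoms and bonds as compound 2 and differs only in how the stereocentre is drawn; the step is a 1.9-fold higher number from compound 2 to compound 3 (0.27 log units; within the scatter), and the only thing that separates the pair is the fact that compounds 2 and 3 differ only in the configuration as drawn. How compound 3 differs from compound 1 is not broken down here.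

Compound 4 `CCCCC[C@H](CO)Nc1nc(N)nc2cccnc12` has not yet been measured. It stands to compound 3 as compound 2 stands to compound 1, the same kind of change rather than the same one: methyl in place of hydrogen on a saturated chain carbon, five bonds along the chain from a nitrogen on an aromatic ring. The place is not identical, since the added methyl now sits five bonds along the chain from the aromatic-ring nitrogen instead of four. The expectation for compound 4 rests on the earlier step, which was a 1.0-fold lower number from compound 1 to compound 2 (0.01 log units; within the scatter). An estimated step of a 1.1-fold lower number from compound 3 to compound 4 (0.05 log units; within the scatter) therefore follows for compound 4. Compound 4 is expected to give about 700 nM, with a likely range from 320 nM to 1600 nM.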

Compound 4, half-maximal effective concentration: 3330 nM
For compound 4 the middle estimate is 4.8-fold (0.68 log units) below the measured one; the measured number lies above the stated range.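

In this assay, the added methyl now has a real effect, with a 4.2-fold higher number from compound 3 to compound 4 (0.62 log units; beyond the scatter), so more compound is needed once the chain has grown by this one carbon. The change therefore does not carry from one core to the other as a fixed step, and the two steps do differ: the same change on two cores in this assay, a 1.0-fold lower number (0.01 log units; within the scatter) from compound 1 to compound 2 and a 4.2-fold higher number (0.62 log units; beyond the scatter) from compound 3 to compound 4, 4.3-fold (0.64 log units) apart, beyond the scatter of two such steps What this does not show is the reason for the difference, since the added methyl sits at a different place along the chain in each pair and the two starting compounds are not the same, and one pair of each kind cannot separate these factors or establish a trend across the series.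

The compounds shown leave open whether the same added methyl would have a similar effect on the other drawn configuration of compound 4, which would show how far the result depends on the stereocentre. They also leave open whether a longer chain would raise the number further, and how an amine or a carboxylic acid would compare with the methyl at this place on the chain.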